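The source may report more compounds than this note shows. Statements on the series, on what has been measured and on what is new or still open speak of the compounds shown alone.

In an ADME assay on MDBK cells (Bos taurus) for cytotoxicity, read by MTT assay, with a stated time of 96 h (a higher number here means that more compound is tolerated, a lower number that less compound is tolerated), compound 1 (`CC(=O)NC(=S)Nc1cccc(C(F)(F)F)c1`) gives > 100000 nM as a limit of the assay. Within the data shown here, compound 2 (`FC(F)(F)c1cccc(NC(=S)Nc2cccc(Br)c2)c1`) gives 10000 nM as the only true number so far. Among the measured compounds shown here, the one measured step, an at least 10-fold lower number from compound 1 to compound 2 (1.00 log units; beyond the scatter) for 3-bromophenyl in place of acetyl, bears only indirectly, since no measured step exchanges one halogen for another. Compound 3 (`Fc1cccc(NC(=S)Nc2cccc(C(F)(F)F)c2)c1`) follows from fluoro in place of bromo on an aromatic carbon with fluoro in place of bromo on an aromatic carbon, and the ring stays. The expected 1.3-fold higher number from compound 2 to compound 3 (0.11 log units; within the scatter) in this assay should stay within the scatter, with no direction favoured. For compound 3 the estimate is 13000 nM as the expected value, within an expected range of 5000 nM to 45000 nM for this compound.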

Compound 3, half-maximal cytotoxic concentration: 10000 nM
Compound 3: middle estimate off by 1.3-fold (0.11 log units), on the high side; the measured number falls inside the stated range.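

Fluoro in place of bromo on the aromatic carbon gives no change at the digits printed from compound 2 to compound 3 (within the scatter) in this assay, so at this position the number does not depend on which of these two halogens is present. The 3-fluorophenyl group in place of acetyl gives an at least 10-fold lower number from compound 1 to compound 3 (1.00 log units; beyond the scatter), which reproduces the drop seen with 3-bromophenyl. Compound 1 stands at a limit, so this step is a bound and not a size: the limit of > 100000 nM in this assay, at which 1 of the 3 values shown sits.

On these data alone, whether the halogen is needed at all remains open, as an unsubstituted phenyl would show. So does the effect of an amine or a carboxylic acid at this position.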